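Chloro for Methoxy on the Pyridin-4-yl Ethenyl Core

The source may hold more compounds than are shown below. What is called first, only, known or untested is meant among the compounds shown, and "the series" means these compounds.

Measured compounds in this assay:
compound 1, `COc1ccc(NC(=O)c2cc(Oc3ccc(/C=C/c4ccccn4)cc3)ccn2)cc1`, 30000 nM
compound 2, `O=C(Nc1ccc(Cl)cc1)c1cc(Oc2ccc(/C=C/c3ccccn3)cc2)ccn1`, 31300 nM
compound 3, `COc1ccc(NC(=O)c2cc(Oc3ccc(/C=C/c4ccncc4)cc3)ccn2)cc1`, > 100000 nM (a limit)

The three compounds were tested in a functional assay on HepG2 cells (Homo sapiens) for antiproliferative activity, read by CCK-8 assay, with a stated time of 48 h; on this read-out higher numbers stand for weaker inhibition and lower numbers for stronger inhibition. Compound 1 gives 30000 nM and compound 2 gives 31300 nM. Compound 3 reaches only the limit of this assay, > 100000 nM. From compound 1 to compound 2 the change is chloro in place of methoxy on an aromatic carbon, and it produced a 1.0-fold higher number from compound 1 to compound 2 (0.02 log units; within the scatter). The two cores differ by pyridin-4-yl in place of pyridin-2-yl on a double-bonded chain carbon bound to a double-bonded chain carbon, a step that read an at least 3.3-fold higher number from compound 1 to compound 3 (0.52 log units; beyond the scatter), with compound 3 sitting at the limit of > 100000 nM in this assay, at which 1 of the 3 values shown sits.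

Compound 4, `O=C(Nc1ccc(Cl)cc1)c1cc(Oc2ccc(/C=C/c3ccncc3)cc2)ccn1`, awaits measurement. It differs from compound 3 by chloro in place of methoxy on an aromatic carbon, the same change as that from compound 1 to compound 2. Compound 4 is expected to show a step that the limit leaves unreadable from compound 3 to compound 4, an expectation resting on the flat earlier step a 1.0-fold higher number from compound 1 to compound 2 (0.02 log units; within the scatter). Compound 4 is therefore estimated at 150000 nM, between 60000 nM and 400000 nM, and most likely again only a limit.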

Compound 4, half-maximal inhibitory concentration: 56200 nM
Compound 4: middle estimate off by 2.7-fold (0.43 log units), on the high side; the whole stated range lies above it.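

Where the chain carries pyridin-4-yl, chloro in place of methoxy gave an at least 1.7-fold lower number from compound 3 to compound 4 (0.25 log units; that floor lies within the scatter) in this assay, a step read against a limit, since compound 3 reached only that. Beside the step with pyridin-2-yl, this does not show that the change carries over unaltered, nor that it behaves differently on the second core: the same change on two cores in this assay, a 1.0-fold higher number (0.02 log units; within the scatter) from compound 1 to compound 2 and an at least 1.7-fold lower number (0.25 log units; that floor lies within the scatter) from compound 3 to compound 4; the limit leaves it open whether they differ The swap of pyridin-2-yl for pyridin-4-yl, which gave a 1.8-fold higher number from compound 2 to compound 4 (0.25 log units; within the scatter) with chloro in place, is equally unsettled against its earlier step: the same change on two cores in this assay, an at least 3.3-fold higher number (0.52 log units; beyond the scatter) from compound 1 to compound 3 and a 1.8-fold higher number (0.25 log units; within the scatter) from compound 2 to compound 4; the limit leaves it open whether they differ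

The compounds shown leave open whether a nitrile or a dimethylamino group on that aromatic carbon would read differently from chloro and methoxy. They also leave open how pyridin-3-yl on the chain would compare with the two pyridinyl groups present.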